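Swapping the Aryl Group on the Hydrazone Carbon

A few compounds are considered here, and "the series" means these few. Any claim that something is new, unique, unknown or untested is made for them only; others in the source may bear on it.

Compound 2 `O=C(N/N=C/c1cccc(O)c1)c1cccnc1Nc1cccc(C(F)(F)F)c1` was tested in a functional assay on the whole organism (strain Wistar) for inhibition, with Rattus norvegicus as the target, read by paw edema, with a stated time of 1 h, at a dose of 10 mg/kg by the intraperitoneal route (a higher number here means more inhibition at the dose given (going by the name of the read-out), a lower number less inhibition), and gives 63.8%. Of the three numbers shown it is the second highest: compound 1 `O=C(N/N=C/c1ccc(Cl)cc1)c1cccnc1Nc1cccc(C(F)(F)F)c1` gives 67.2%, and compound 3 `COc1cc(/C=N/NC(=O)c2cccnc2Nc2cccc(C(F)(F)F)c2)cc(OC)c1OC` gives 54.4%, both within the scatter of compound 2. Going by the values given here, the only measured step, a number 3.4 percentage points lower from compound 1 to compound 2 (within the scatter), shows that exchanging the aryl group on the carbon with a double bond to nitrogen moved inhibition by no more than the scatter. Compound 4 `CN(C)c1ccc(/C=N/NC(=O)c2cccnc2Nc2cccc(C(F)(F)F)c2)cc1` differs from compound 2 at that same carbon: 4-(dimethylamino)phenyl in place of 3-hydroxyphenyl on a carbon with a double bond to nitrogen. Among the compounds with values here, no measured step covers this exact exchange, but the one step of this kind was small, so from compound 2 to compound 4 a step of a number 1.8 percentage points lower from compound 2 to compound 4 (within the scatter) is expected, nothing beyond the scatter. Compound 4 is therefore estimated to give 62%, between 50% and 74%.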

Compound 4, a percentage reported as inhibition, in the whole organism at one dose (the size of the read-out at that dose, not a potency): 63.5%
Compound 4: middle estimate off by 1.5 percentage points, on the low side; low and high end bracket the measured number.
By their numbers in this assay, from the lowest: compounds 3, 4, 2 and 1 (each within the scatter of the next, the first and the last beyond it).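

In this assay, a second exchange at the carbon with a double bond to nitrogen also stays small: a number 0.3 percentage points lower from compound 2 to compound 4 (within the scatter), even though 3-hydroxyphenyl carries a hydrogen-bond donor and 4-(dimethylamino)phenyl carries none. Dimethylamino in place of chloro on an aromatic carbon likewise gives a number 3.7 percentage points lower from compound 1 to compound 4 (within the scatter), so this change also stays within the scatter.

As far as these compounds go, whether a non-aromatic group such as cyclohexyl, or a phenyl ring bearing a carboxylic acid, would also stay within the scatter remains open. Nothing available explains why these steps are small.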